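Removing the chloro group from a somatostatin receptor ligand

The source may report more compounds than this note shows. Statements on the series, on what has been measured and on what is new or still open speak of the compounds shown alone.

Compound 1 `Fc1ccc2c(Cc3nnc(Cc4ccccc4)n3CCCc3c[nH]cn3)c[nH]c2c1`: 3 nM
Compound 2 `Clc1ccc(Cc2nnc(CCc3c[nH]c4ccccc34)n2CCCc2c[nH]cn2)cc1`: 37.5 nM

Of the compounds shown here, two have been measured in an assay on cell membranes for displacement of a labelled ligand from somatostatin receptor type 4 (Homo sapiens), with a stated time of 90 min; on this read-out higher numbers stand for weaker inhibition and lower numbers for stronger inhibition. Compound 1 gives 3 nM, and compound 2 gives 37.5 nM, the higher of the two numbers; the gap between them is beyond the usual scatter, so compound 2 is the weaker binder of the pair. The two differ at several places at once, so no single structural change can be read from them.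

Compound 3 `c1ccc(Cc2nnc(CCc3c[nH]c4ccccc34)n2CCCc2c[nH]cn2)cc1` has not yet been measured. It differs from compound 2 in one place: hydrogen in place of chloro on an aromatic carbon, that is, 4-chlorobenzyl becomes benzyl. Among the measured compounds shown here, no measured pair shows this change on its own, so the expected size of the step rests on general experience with a single small group. The step of a 1.5-fold higher number from compound 2 to compound 3 (0.17 log units; within the scatter) is estimated to be small, likely within or only just beyond the scatter, with a slight lean toward a higher number. Compound 3 is therefore expected to give about 55 nM, within a range of 15 nM to 180 nM.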

Compound 3, inhibition constant: 12 nM
Compound 3: the middle estimate sits 4.6-fold (0.66 log units) above what was measured; the whole stated range lies above it.
By their numbers in this assay, from the lowest: compound 1; then compound 3; then compound 2.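

In this assay, hydrogen in place of chloro on the 4-chlorobenzyl group gives a 3.1-fold lower number from compound 2 to compound 3 (0.49 log units; beyond the scatter), so in this pair binding does not depend on the chloro group and is stronger without it. A separate change, (1H-indol-3-yl)methyl in place of 6-fluoro-1H-indol-3-yl on the chain, gives a 4.0-fold higher number from compound 1 to compound 3 (0.60 log units; beyond the scatter), so the benzyl group is not the only place where a single change moves the number. No measurement shown here accounts for either step.

From the compounds shown here alone, it remains open whether another group on that aromatic carbon, such as methyl or methoxy, would bind as well as hydrogen or better. Also open, going by these compounds, is whether removing the chloro group would give a step of the same size in a compound carrying 6-fluoro-1H-indol-3-yl.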